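From bromo to methyl on the shared core

The source may report more compounds than this note shows. Statements on the series, on what has been measured and on what is new or still open speak of the compounds shown alone.

Compound 1 `COC(=O)[C@@]1(C)C[C@@H](c2coc3ccc(Br)cc3c2=O)N(c2ccccc2)O1` gives > 60000 nM in a functional assay on Caco-2 cells (Homo sapiens) for inhibition, read by sulforhodamine B assay, with a stated time of 48 h (a lower number here means a stronger inhibitor, a higher number a weaker inhibitor), and that reading is only a limit of the assay. Compound 3 `N#C[C@H]1C[C@@H](c2coc3ccc(Cl)cc3c2=O)N(c2ccccc2)O1` gives 39000 nM in this assay as a true number. Within the data shown here, compound 4 `COC(=O)[C@@]1(C)C[C@@H](c2coc3ccc(C)cc3c2=O)N(c2ccccc2)O1` keeps the core of compound 1 but has methyl in place of bromo on an aromatic carbon and no measured pair isolates that swap. Compound 2 `CCO[C@H]1C[C@@H](c2coc3ccc(C)cc3c2=O)N(c2ccccc2)O1` carries the same methyl, differs elsewhere, and gives 31000 nM in this assay so only a modest move toward stronger inhibition is expected. The expected change is an at least 1.3-fold lower number from compound 1 to compound 4 (0.12 log units; that floor lies within the scatter) and it may not clear the usual scatter. Compound 4 is estimated at 45000 nM in this assay with a likely range from 22000 nM to 85000 nM and it could also end up only as a limit.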

Compound 4, half-maximal inhibitory concentration: 19700 nM
For compound 4 the middle estimate is 2.3-fold (0.36 log units) above the measured one, and the stated range ends above it.
By their numbers in this assay, from the lowest: compounds 4, 2 and 3 (each within the scatter of the next). At a limit, above all of these: compound 1.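

On the shared core, this position on the aromatic ring does respond to the change. In this assay, among these compounds, methyl in place of bromo gives an at least 3.0-fold lower number from compound 1 to compound 4 (0.48 log units; beyond the scatter), which no earlier pair could isolate. Compound 1 reads only as a limit of the assay, so this step is a floor and its full size stays unknown: the limit of > 60000 nM in this assay, at which 1 of the 4 values shown sits.

The compounds shown leave open whether a different group at this place, such as an amine, a carboxylic acid or a longer chain, would lower the number further. As far as these compounds go, whether the same swap gives a similar step on a different core also remains open.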